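Piperidine-nitrogen substitution in a thiol acid series

A few compounds are considered here, and "the series" means these few. Any claim that something is new, unique, unknown or untested is made for them only; others in the source may bear on it.

Working notes on a small set of thiol acids sharing one core. Going by the values given here, compound 1, `O=C(O)C(CS)C1CCNCC1`, carries an unsubstituted ring nitrogen and in an assay on isolated protein for inhibition of carboxypeptidase N catalytic chain (Homo sapiens) (on this read-out higher numbers stand for weaker inhibition and lower numbers for stronger inhibition), gives 60 nM, the only value shown for it, with a further entry that reports no single number. Compound 2, `N=C(N)N1CCCC(C(CS)C(=O)O)C1`, bears a guanidine on its ring nitrogen and in this assay gives 58 nM; 38 nM (2 entries), entries that sit close to one another and close to the value of compound 1 (the several entries of compound 2 in this assay, 58 nM; 38 nM (2 entries)). Compound 3, `CC(=N)N1CCC(C(CS)C(=O)O)CC1`, is not yet measured; it differs from compound 1 by a group of 3 heavy atoms (2 carbon, 1 nitrogen; no ring) in place of a hydrogen atom, on an amine nitrogen in a ring. Among the compounds with values here, no step between measured compounds is available, so the expectation rests only on the two values above. The step from compound 1 to compound 3 is expected to be small, toward stronger inhibition or none beyond the usual scatter, a 1.5-fold lower number from compound 1 to compound 3 (0.18 log units; within the scatter). Compound 3 is accordingly estimated at 40 nM, within 15 nM to 120 nM.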

Compound 3, half-maximal inhibitory concentration: 29000 nM
The estimate for compound 3 lay 730-fold (2.86 log units) below the measured number; measured number above the stated range.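

In this assay, the amine nitrogen in the ring of the shared core proves to be a place where one small change has a very large effect: a group of 3 heavy atoms (2 carbon, 1 nitrogen; no ring) in place of the hydrogen atom gives a 480-fold higher number from compound 1 to compound 3 (2.68 log units; beyond the scatter). Going by these compounds alone, no step at this nitrogen could be read before, and compound 2, which carries a guanidine on its ring nitrogen, differs from compound 1 in more than one place, so its values cannot stand in for such a step. The size of the new step lies far outside the spread of repeated entries on this read-out, so it is not an artefact of repeat variation: the several entries of compound 2 in this assay, 58 nM; 38 nM (2 entries)

The compounds shown do not tell whether the loss belongs to this particular group, with its double bond outside any ring, or to any replacement of the hydrogen atom on this nitrogen. A plain methyl or an acetyl on the same nitrogen of the core of compound 1 would separate these two readings, and a single step cannot settle the matter.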